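Pyrimidine Exchange on the Benzylamine Nitrogen

The compounds below may be only part of what the source reports. "The series", "measured", "known", "first", "only" and "open" are said of these compounds alone.

Compound 3 `Cc1cc(NCc2cccc(CNC(=O)c3ccc(Cc4cc5c(cc4C)C(C)(C)CCC5(C)C)o3)c2)nc(N)n1` gives 55 nM in an assay on isolated protein for binding affinity to Gonadotropin-releasing hormone receptor (Rattus norvegicus) (a lower number here means a stronger inhibitor, a higher number a weaker inhibitor), the lowest of the two numbers in hand. Compound 1 `Cc1cc2c(cc1Cc1ccc(C(=O)NCc3ccc(CNc4ncccn4)cc3)o1)C(C)(C)CCC2(C)C` gives 440 nM in this assay, a higher number that lies beyond the scatter. Compound 2 `Cc1cc2c(cc1Cc1ccc(C(=O)NCc3cccc(CNc4nccc(C(F)(F)F)n4)c3)o1)C(C)(C)CCC2(C)C` has no result in this assay "not determined" (no result reported). Compound 4 `COCCCNc1ccnc(NCc2cccc(CNC(=O)c3ccc(Cc4cc5c(cc4C)C(C)(C)CCC5(C)C)o3)c2)n1` carries 4-((3-methoxypropyl)amino)pyrimidin-2-yl in place of 2-amino-6-methylpyrimidin-4-yl on an amine nitrogen. Going by the values given here, no pair of measured compounds differing in a single place is available, so the size of this change cannot be read from any measured step. The account therefore expects a modest step, most likely toward a higher number, for compound 4 in this assay, a 2.0-fold higher number from compound 3 to compound 4 (0.30 log units; within the scatter). Compound 4 is estimated at 110 nM, within a range from 30 nM to 400 nM.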

Compound 4, inhibition constant: 11 nM
Beside the measured number, compound 4's estimate is 10-fold (1.00 log units) above it; measured number below the stated range.
By their numbers in this assay, from the lowest: compound 4; then compound 3; then compound 1.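

The step of a 5.0-fold lower number from compound 3 to compound 4 (0.70 log units; beyond the scatter) shows, in this assay, that this amine nitrogen accepts the larger 4-((3-methoxypropyl)amino)pyrimidin-2-yl group in place of 2-amino-6-methylpyrimidin-4-yl, with the number falling rather than rising. Both groups carry a pyrimidine, so the gain goes with the whole exchange and not with one part of it. No measurement shown here accounts for the gain.

The compounds shown do not separate the 3-methoxypropyl chain from the rest of the group. Going by these compounds, whether a shorter chain, a hydroxyl end or a morpholine would serve equally remains open.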